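From 2-fluoropyridin-4-yl to 1,2-thiazol-3-yl on an oxygen

The source may hold more compounds than are shown below. What is called first, only, known or untested is meant among the compounds shown, and "the series" means these compounds.

In an ADME assay on the whole organism (plasma, Rattus norvegicus) for protein binding, at a dose of 3 mg/kg by the intravenous route (a higher number here means a larger unbound share of the compound, a lower number a smaller unbound share), compound 1 `C[C@@H](Cn1c(=O)[nH]/c(=N\c2ccc(Oc3ccccn3)cc2)n(Cc2ccc(Cl)cc2)c1=O)C(=O)O` gives 0.01 and compound 2 `C[C@@H](Cn1c(=O)[nH]/c(=N\c2ccc(Oc3ccnc(F)c3)cc2)n(Cc2ccc(Cl)cc2)c1=O)C(=O)O` gives 0.013 with the two values lying within the scatter of each other. Compound 3 `C[C@@H](Cn1c(=O)[nH]/c(=N\c2ccc(Oc3ccsn3)cc2)n(Cc2ccc(Cl)cc2)c1=O)C(=O)O` carries 1,2-thiazol-3-yl in place of 2-fluoropyridin-4-yl on an oxygen on an aromatic ring, a change counted as 1,2-thiazol-3-yl in place of 2-fluoropyridin-4-yl on an oxygen on an aromatic ring in full. Within the data shown here, only one measured step bears on this, another exchange of the group on that oxygen: a 1.3-fold higher number from compound 1 to compound 2 (0.11 log units; within the scatter). The expected step is therefore small, a 1.2-fold higher number from compound 2 to compound 3 (0.06 log units; within the scatter) and no change beyond the scatter is expected. Compound 3 is estimated to give 0.015 with an expected range from 0.007 to 0.03 in this assay.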

Compound 3, unbound fraction: 0.012
Compound 3: middle estimate off by 1.3-fold (0.10 log units), on the high side; low and high end bracket the measured number.
By their numbers in this assay, from the lowest: compounds 1, 3 and 2 (each within the scatter of the next).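

In this assay, a five-membered aromatic ring with 2 hetero atoms on the oxygen reads no differently from either six-membered ring, with a 1.1-fold lower number from compound 2 to compound 3 (0.03 log units; within the scatter) and a 1.2-fold higher number from compound 1 to compound 3 (0.08 log units; within the scatter). Three different aromatic rings at this position, in compounds 1, 2 and 3, thus all stay within the scatter of one another, and the smaller ring brings no change that can be read. No measured evidence bears on this result. The compounds shown leave open whether a non-aromatic group on that oxygen, such as an aminoethyl chain, would move the unbound fraction beyond the scatter.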